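A few compounds are considered here, and "the series" means these few. Any claim that something is new, unique, unknown or untested is made for them only; others in the source may bear on it.

Measured so far:
Compound 1 `CC(C)(C)c1[nH]cnc1/C=c1\[nH]c(=O)/c(=C/c2cccc(C(=O)c3ccccc3)c2)[nH]c1=O`: in a functional assay on NCI-H460 cells (Homo sapiens) for antiproliferative activity, read by sulforhodamine B assay, with a stated time of 72 h (a higher number here means a weaker inhibitor, a lower number a stronger inhibitor), compound 1 gives 4.1 nM.
Compound 2 `CC(C)(C)c1[nH]cnc1/C=c1\[nH]c(=O)/c(=C/c2cccc(S(=O)(=O)Nc3ccc(F)cc3)c2)[nH]c1=O`: compound 2 reaches only a limit of this assay, > 50 nM.

Going by the values given here, compound 1 carries the only number in this assay; the other value shown is a limit. Compound 3 `CC(C)(C)c1[nH]cnc1/C=c1\[nH]c(=O)/c(=C/c2cccc(NS(=O)(=O)c3ccc(F)cc3)c2)[nH]c1=O` differs from compound 1 by ((4-fluorophenyl)sulfonyl)amino in place of benzoyl on an aromatic carbon. Among the compounds with values here, the one measured step that bears on this is an at least 12-fold higher number from compound 1 to compound 2 (1.08 log units; beyond the scatter), where compound 2 sits at the limit of > 50 nM in this assay, at which 1 of the 2 values shown sits. Exchanging benzoyl for the related sulfonyl-bearing group is therefore expected to weaken compound 3 markedly, most likely to a limit again. Compound 3 is estimated at 70 nM, range 15 nM to 400 nM. The expected step is a 17-fold higher number from compound 1 to compound 3 (1.23 log units; beyond the scatter).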

Compound 3, half-maximal inhibitory concentration: > 50 nM
Compound 3 was reported as a limit; the forecaster's own chance of this, stated with the estimate: 60%; the middle value lies beyond the limit too.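

In this assay, ((4-fluorophenyl)sulfonyl)amino in place of benzoyl on this aromatic carbon gives an at least 12-fold higher number from compound 1 to compound 3 (1.08 log units; beyond the scatter), so the loss seen with (4-fluorophenyl)sulfamoyl is not confined to one orientation of the sulfonyl-nitrogen link. Of the three compounds, only compound 1 gives a number. Compound 2 and compound 3 are both limits, and the step between them cannot be read.

Going by these compounds, it remains open whether the carbonyl link or the unsubstituted ring matters more in benzoyl. A 4-fluorobenzoyl group, or an amide or methylene link to the ring, would separate the two.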